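Swapping trifluoromethoxy for fluorine on the sulfonyl ring

The source may hold more compounds than are shown below. What is called first, only, known or untested is meant among the compounds shown, and "the series" means these compounds.

Compound 1 `CCN(CC)c1ccc2cc(C(=O)c3ccc(N4CCN(C(=O)CN5CCNCC5)CC4)cc3)oc2c1` carries a free ring amine at its far end, and in a functional assay on MCF7 cells (Homo sapiens) for cytotoxicity, read by MTT assay, with a stated time of 48 h (on this read-out higher numbers stand for weaker inhibition and lower numbers for stronger inhibition), compound 1 gives 5340 nM. Compound 2 `CCN(CC)c1ccc2cc(C(=O)c3ccc(N4CCN(C(=O)CN5CCN(S(=O)(=O)C6CC6)CC5)CC4)cc3)oc2c1` puts a cyclopropylsulfonyl on that nitrogen. For compound 2 this assay reports only a limit, > 40000 nM, not a number. The step of an at least 7.4-fold higher number from compound 1 to compound 2 (0.87 log units; beyond the scatter) therefore weakened inhibition, as far as the limit of > 40000 nM in this assay, at which 1 of the 3 values shown sits, allows one to say. Compound 3 `CCN(CC)c1ccc2cc(C(=O)c3ccc(N4CCN(C(=O)CN5CCN(S(=O)(=O)c6ccc(OC(F)(F)F)cc6)CC5)CC4)cc3)oc2c1` replaces the cyclopropyl by a 4-(trifluoromethoxy)phenyl group, and in this assay compound 3 gives 20100 nM. The step of an at least 1.9-fold lower number from compound 2 to compound 3 (0.29 log units; that floor lies within the scatter) points back toward stronger inhibition, though its floor sits within the scatter. Among the two plain numbers compound 3 holds the higher one, and its gap to compound 1 lies beyond the usual scatter.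

Compound 4 `CCN(CC)c1ccc2cc(C(=O)c3ccc(N4CCN(C(=O)CN5CCN(S(=O)(=O)c6ccc(F)cc6)CC5)CC4)cc3)oc2c1` differs from compound 3 in one place: fluoro in place of trifluoromethoxy on an aromatic carbon. Going by the values given here, the only measured steps that bear on this region are the two above, which changed the whole sulfonyl substituent and moved the number modestly or to a limit. Trimming the trifluoromethoxy to a single fluorine is a smaller change, so the expected step of a 1.2-fold higher number from compound 3 to compound 4 (0.09 log units; within the scatter) is small and of uncertain direction. Compound 4 is estimated at 25000 nM, expected between 9000 nM and 60000 nM.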

Compound 4, half-maximal inhibitory concentration: 20500 nM
The estimate for compound 4 lay 1.2-fold (0.09 log units) above the measured number, and the stated range covers the measured number.
By their numbers in this assay, from the lowest: compound 1; then compounds 3 and 4 (each within the scatter of the next). At a limit, above all of these: compound 2.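

In this assay, going by these compounds alone, the step of a 1.0-fold higher number from compound 3 to compound 4 (0.01 log units; within the scatter) shows that, on this aromatic carbon para to a large group, exchanging the five heavy atoms of trifluoromethoxy for the single fluorine changes nothing that can be read. The step of a 3.8-fold higher number from compound 1 to compound 4 (0.58 log units; beyond the scatter) shows that compound 4, like compound 3, stays modestly weaker than the free ring amine of compound 1, so that gap does not depend on trifluoromethoxy being present. Against the cyclopropyl group the comparison gives only a floor within the scatter, the step of an at least 1.9-fold lower number from compound 2 to compound 4 (0.29 log units; that floor lies within the scatter), and it rests on a limit for compound 2: the limit of > 40000 nM in this assay, at which 1 of the 4 values shown sits.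

Only trifluoromethoxy and fluoro are shown at this ring carbon, so it remains open whether an amine, a carboxylic acid or a longer chain there would also leave the number unchanged. As far as these compounds go, it also remains open whether the gap to compound 1 follows from the sulfonyl link or from what that link carries, a question that a simple acetyl or methyl group on the same ring nitrogen would help to separate.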